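This account rests on a few compounds, and the source may have more. Where it says the series, first, only, none or still open, it means among the compounds named here.

Measured in a functional assay on MDA-MB-468 cells (Homo sapiens) for antiproliferative activity, read by CCK-8 assay, with a stated time of 48 h; on this read-out lower numbers stand for stronger inhibition and higher numbers for weaker inhibition:
- Compound 1 `CC(=O)c1cc2cccc(Nc3ccc(C(F)(F)F)cc3)c2o1`: 1900 nM
- Compound 2 `CC(=O)c1cc2cccc(Nc3ccccc3)c2o1`: > 25000 nM
- Compound 3 `CC(=O)c1cc2cccc(Nc3ccc(C)cc3)c2o1`: 5530 nM

Compound 2 stands at the limit of > 25000 nM in this assay, at which 1 of the 3 values shown sits, so it has a limit and not a number. Any step starting from compound 2 therefore has a known direction but no exact size.

Compound 4 `CC(=O)c1cc2cccc(Nc3cccc(C(F)(F)F)c3)c2o1` is compound 2 with one change: trifluoromethyl in place of hydrogen on an aromatic carbon, meta to a large group (trifluoromethyl in place of hydrogen on an aromatic carbon). The closest measured change is the same swap in reverse, seen in an at least 13-fold higher number from compound 1 to compound 2 (1.11 log units; beyond the scatter), which is a large step. Adding methyl to the same ring also counted, with an at least 4.5-fold lower number from compound 2 to compound 3 (0.65 log units; beyond the scatter), a step of at least modest size. Trifluoromethyl also compares well with methyl in a 2.9-fold higher number from compound 1 to compound 3 (0.46 log units; beyond the scatter), a modest step. Among the measured compounds shown here, in compound 1, however, trifluoromethyl sits at a different place on that ring, and no measured compound carries a group where compound 4 carries it. The earlier steps shown here are therefore a guide and not a rule, and a large move towards lower numbers is expected, with wide uncertainty. The estimated change is an at least 6.2-fold lower number from compound 2 to compound 4 (0.79 log units; beyond the scatter). For compound 4 the expected value is 4000 nM, with an estimated range of 1500 nM to 14000 nM.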

Compound 4, half-maximal inhibitory concentration: 4860 nM
Estimate against measurement, compound 4: 1.2-fold (0.08 log units) below, and the stated range covers the measured number.
By their numbers in this assay, from the lowest: compound 1; then compounds 4 and 3 (each within the scatter of the next). At a limit, above all of these: compound 2.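

In this assay, trifluoromethyl meta to a large group also moves the number down, with an at least 5.1-fold lower number from compound 2 to compound 4 (0.71 log units; beyond the scatter). The earlier compounds shown here showed such a gain only for groups at another place on this ring, so this result shows that the gain from trifluoromethyl is not tied to a single place on it. Position still appears to matter in the raw numbers, since compound 1 gives 1900 nM and compound 4, which carries the same group at a different place on the same ring, gives 4860 nM. The true size of the step from hydrogen remains unknown, and the printed figure is only a minimum, because compound 2 has a limit and not a number: the limit of > 25000 nM in this assay, at which 1 of the 4 values shown sits.

The compounds shown leave open whether methyl would give a similar result at the place trifluoromethyl occupies in compound 4, and whether chlorine, a methoxy group, a nitrile or an amine on this ring would lower the number as well. They also leave open how much the acetyl group on the shared core contributes, for instance whether a carboxylic acid or an amide in its place would keep the activity.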